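A few compounds are considered here, and "the series" means these few. Any claim that something is new, unique, unknown or untested is made for them only; others in the source may bear on it.

Measured compounds:
- compound 1 `COc1ccc(-c2cc(C(=O)/C=C/c3ccc(C)cc3)nc3cc(-c4ccccc4)nn23)cc1OC`; in a functional assay on A549 cells (Homo sapiens) for antiproliferative activity, read by MTT assay, with a stated time of 24 h (a lower number here means a stronger inhibitor, a higher number a weaker inhibitor), compound 1 gives 22200 nM.
- compound 2 `COc1cc(-c2cc(C(=O)/C=C/c3ccc(C)cc3)nc3cc(-c4ccccc4)nn23)cc(OC)c1OC`; in this assay compound 2 gives 20000 nM.

For the measured compounds named here, compound 1 carries the higher of the two numbers, but the only step to it, a 1.1-fold lower number from compound 1 to compound 2 (0.05 log units; within the scatter), is within the scatter, so the two compounds are not separated. Compound 3 `COc1ccc(-c2cc(/C=C/C(=O)c3ccc(Cl)cc3)nc3cc(-c4ccccc4)nn23)cc1OC` is not yet measured. It differs from compound 1 by 2-((4-chlorophenyl)carbonyl)ethenyl in place of (2-(4-methylphenyl)ethenyl)carbonyl on an aromatic carbon. Going by the values given here, the single measured step, a 1.1-fold lower number from compound 1 to compound 2 (0.05 log units; within the scatter), concerns a methoxy added elsewhere on the shared core and does not bear on an exchange of this kind; no measured pair shows what such a change does. Without a bearing step, the working expectation is that compound 3 stays near compound 1, with no step beyond the scatter and a wide range to reflect the lack of guidance. Compound 3 is thus estimated at 20000 nM, with a range from 6000 nM to 60000 nM. The expected step is a 1.1-fold lower number from compound 1 to compound 3 (0.05 log units; within the scatter).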

Compound 3, half-maximal inhibitory concentration: 15400 nM
Beside the measured number, compound 3's estimate is 1.3-fold (0.11 log units) above it; low and high end bracket the measured number.
By their numbers in this assay, from the lowest: compounds 3, 2 and 1 (each within the scatter of the next).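

In this assay, the exchange at this aromatic carbon gives a 1.4-fold lower number from compound 1 to compound 3 (0.16 log units; within the scatter), and compound 1 and compound 3 are not separated. The exchange alters two things at once: the carbonyl stands at the other end of the ethenyl link, and a 4-chlorophenyl replaces a 4-methylphenyl, and this single pair cannot show what either alteration does alone. Nothing measured here accounts for the result.

Open, going by these compounds, is whether an amine or a carboxylic acid in place of the chlorine of compound 3 gives a step beyond the scatter. Also open, on these data alone, is whether the same exchange on the core of compound 2, with its added methoxy, gives a step of like size.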